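Replacing an aryl carbonyl by an arylamino carbonyl

The source may hold more compounds than are shown below. What is called first, only, known or untested is meant among the compounds shown, and "the series" means these compounds.

Measured compounds:
Compound 1 `O=C(Nc1cccc(-n2cc(-c3ccncc3)c(-c3ccc(Cl)c(O)c3)n2)c1)Nc1cccc(C(F)(F)F)c1` gives 29200 nM in a functional assay on SF-295 cells (Homo sapiens) for inhibition, read by sulforhodamine B assay, with a stated time of 48 h; a lower number here means that less compound is tolerated, a higher number that more compound is tolerated.
Compound 2 `COc1cc(-c2nn(-c3cccc(NC(=O)Nc4cc(C(F)(F)F)cc(C(F)(F)F)c4)c3)cc2-c2ccncc2)ccc1Cl` gives 3310 nM in this assay.
Compound 3 `COc1cc(-c2nn(-c3cccc(NC(=O)c4cccc(C(F)(F)F)c4)c3)cc2-c2ccncc2)ccc1Cl` gives > 50000 nM in this assay.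

Compound 3 stands apart from the other two: its value is only a limit of the assay, not a number, and the limit of > 50000 nM in this assay, at which 1 of the 3 values shown sits, marks it as the one entry sitting at that limit. Compound 1 and compound 2, both of which carry an amino group on the carbonyl carbon rather than a directly attached aryl ring, give measurable values, and the gap between them lies beyond the usual scatter.

Compound 4 `COc1cc(-c2nn(-c3cccc(NC(=O)Nc4ccc(Cl)c(Cl)c4)c3)cc2-c2ccncc2)ccc1Cl` has not yet been measured. It differs from compound 3 in one place: (3,4-dichlorophenyl)amino in place of 3-(trifluoromethyl)phenyl on a carbonyl carbon. With this change compound 4 comes to resemble compound 1 and compound 2 in the way the carbonyl carbon is substituted, and those two compounds give measurable values in this assay.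

Compound 4 is therefore expected to move from the limit into the measurable range, a step estimated as an at least 6.2-fold lower number from compound 3 to compound 4 (0.79 log units; beyond the scatter). The estimate for compound 4 in this assay is 8000 nM, with a range from 2000 nM to 40000 nM.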

Compound 4, concentration lethal to 50% of the cells: > 50000 nM
Compound 4: no number, only a limit (the forecaster's own chance of this, stated with the estimate: 20%); middle value at least 6.2-fold (0.79 log units) away from the limit.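

In this assay compound 3 gives > 50000 nM, which is a limit and not a number. Compound 4 gives > 50000 nM, also a limit, so no step between the two can be read, and both stand at the same limit: the limit of > 50000 nM in this assay, at which 2 of the 4 values shown sit.

The compounds shown leave open whether this change alters the value at all, since neither compound has a number.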